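Working notes: from compound 3 to compound 4

The compounds below may be only part of what the source reports. "The series", "measured", "known", "first", "only" and "open" are said of these compounds alone.

Measured so far in a functional assay on MGC-803 cells (Homo sapiens) for inhibition, read by sulforhodamine B assay; on this read-out lower numbers stand for stronger inhibition and higher numbers for weaker inhibition 
- compound 1 `O=C1C=C(Nc2ccccc2F)C(=O)c2c1nc1n2[C@H]2OC[C@@H](O)[C@H]2OC1` gives 2080 nM 
- compound 2 `CCc1ccc(NC2=CC(=O)c3nc4n(c3C2=O)[C@H]2OC[C@@H](O)[C@H]2OC4)cc1` gives 1290 nM 
- compound 3 `O=C1C=C(Nc2ccc(Br)cc2)C(=O)c2c1nc1n2[C@H]2OC[C@@H](O)[C@H]2OC1` gives 1010 nM 

Compound 3 cannot be told apart from compound 2 (a 1.3-fold lower number from compound 2 to compound 3 (0.11 log units; within the scatter)), and it stands a modest margin clear of compound 1 (a 2.1-fold lower number from compound 1 to compound 3 (0.31 log units; beyond the scatter)). The next structure is compound 4 `O=C1C=C(Nc2ccc(C(F)(F)F)cc2)C(=O)c2c1nc1n2[C@H]2OC[C@@H](O)[C@H]2OC1`, reached by trifluoromethyl in place of bromo on an aromatic carbon with trifluoromethyl in place of bromo on an aromatic carbon, para to a large group.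

The closest evidence is the earlier exchange of ethyl for bromo on an aromatic carbon (a 1.3-fold lower number from compound 2 to compound 3 (0.11 log units; within the scatter)), which stayed within the scatter. The change of phenyl substituent behind a 1.6-fold lower number from compound 1 to compound 2 (0.21 log units; within the scatter) also stayed within it. Among the measured compounds shown here, only the step from compound 1 to compound 3 passed the scatter, and only narrowly. For the measured compounds named here, no measured compound carries trifluoromethyl, so the data give no direction for this exchange. No step beyond the scatter is therefore expected in this assay here. The expected change is small (a 1.1-fold higher number from compound 3 to compound 4 (0.04 log units; within the scatter)) and is estimated to remain within the scatter. For compound 4 the estimated value is 1100 nM with an expected range from 500 nM to 2400 nM in this assay.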

Compound 4, half-maximal inhibitory concentration: 2820 nM
The estimate for compound 4 lay 2.6-fold (0.41 log units) below the measured number; the measured number lies above the stated range.
By their numbers in this assay, from the lowest: compounds 3, 2, 1 and 4 (each within the scatter of the next, the first and the last beyond it).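

In this assay the aromatic carbon para to a large group proves sensitive to its substituent: trifluoromethyl in place of bromo gives a 2.8-fold higher number from compound 3 to compound 4 (0.45 log units; beyond the scatter) and trifluoromethyl in place of ethyl gives a 2.2-fold higher number from compound 2 to compound 4 (0.34 log units; beyond the scatter), both modest but beyond the scatter, whereas the earlier exchange at this carbon gave only a 1.3-fold lower number from compound 2 to compound 3 (0.11 log units; within the scatter). The gain that 4-bromophenyl showed over 2-fluorophenyl therefore does not carry over to every group at this carbon, since 4-(trifluoromethyl)phenyl in place of 2-fluorophenyl gives a 1.4-fold higher number from compound 1 to compound 4 (0.13 log units; within the scatter), which leaves those two compounds indistinguishable. Nothing measured here accounts for the difference between trifluoromethyl and the other two groups at this carbon.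

Going by these compounds, it remains open whether the weaker result belongs to trifluoromethyl alone or extends to other groups at this carbon, such as a nitrile, a methoxy or a carboxylic acid. On these data alone, how trifluoromethyl would combine with a second group on the same ring, such as a chloro, also remains open.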